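The compounds below may be only part of what the source reports. "The series", "measured", "known", "first", "only" and "open" are said of these compounds alone.

Compound 2 `O=C(Nc1cc(Nc2ccc(F)c(Cl)c2)ncn1)Nc1c(Cl)cccc1Cl` gives 53.7% in a functional assay on HCC827 cells (Homo sapiens) for inhibition, read by MTT assay, with a stated time of 48 h, tested at 10 uM (on this read-out lower numbers stand for less inhibition and higher numbers for more inhibition at the one concentration tested (going by the name of the read-out)), the lower of the two numbers measured; compound 1 `COc1ccc(F)cc1Nc1cc(NC(=O)Nc2c(Cl)cccc2Cl)ncn1` gives 78%, and the step of a number 24.3 percentage points lower from compound 1 to compound 2 (beyond the scatter) lies beyond the scatter. Compound 3 `Cc1cc(F)cc(Nc2cc(NC(=O)Nc3c(Cl)cccc3Cl)ncn2)c1` differs from compound 2 by 3-fluoro-5-methylphenyl in place of 3-chloro-4-fluorophenyl on a nitrogen on an aromatic ring. Among the measured compounds shown here, the only measured step that touches this position is the one from compound 1 to compound 2, a modest loss, and it shows that swapping the group on that nitrogen can move this assay by a modest step in either direction. For compound 3 a modest gain is therefore expected, a number 8.3 percentage points higher from compound 2 to compound 3 (within the scatter), giving an estimate of 62% with a range from 40% to 84%.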

Compound 3, a percentage reported as inhibition, at one concentration (the size of the read-out at that concentration, not a potency): 49.1%
The estimate for compound 3 lay 12.9 percentage points above the measured number, within the range that was stated.
By their numbers in this assay, from the lowest: compounds 3 and 2 (each within the scatter of the next); then compound 1.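

In this assay, the step of a number 4.6 percentage points lower from compound 2 to compound 3 (within the scatter) shows that this position can take a different substituted phenyl group, with 3-fluoro-5-methylphenyl replacing 3-chloro-4-fluorophenyl, without a change beyond the scatter. The step of a number 28.9 percentage points lower from compound 1 to compound 3 (beyond the scatter) sets compound 1 apart from compound 3 as well, so 5-fluoro-2-methoxyphenyl now stands clear of both other groups on this nitrogen. No evidence is at hand to explain these results. From the compounds shown here alone, it remains open which part of 5-fluoro-2-methoxyphenyl goes with the higher number. Going by these compounds, how a cyclohexyl group or a pyridine ring on this nitrogen would read also remains open.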